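The compounds below may be only part of what the source reports. "The series", "measured", "known", "first", "only" and "open" are said of these compounds alone.

Measured compounds:
compound 1 `CN1CCN(c2ccc([N+](=O)[O-])c(NC(c3ccccc3)c3ccccc3)c2)CC1`: 4490 nM
compound 2 `CN1CCN(c2ccc([N+](=O)[O-])c(NCc3cccnc3)c2)CC1`: 1270 nM

In an assay on HEK293 cells for displacement of a labelled ligand from 5-hydroxytryptamine receptor 6 (Homo sapiens) (a lower number here means a stronger inhibitor, a higher number a weaker inhibitor), compound 1 gives 4490 nM, while compound 2 gives 1270 nM. Of these two numbers compound 2 stands lowest; compound 1 returns a higher number, and the gap between them lies beyond the usual scatter of repeated measurements. For the measured compounds named here, no pair of measured compounds differing in a single place is available, so the size of any one structural step cannot be read from these two values alone.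

Compound 3 `CN1CCN(c2ccc([N+](=O)[O-])c(Nn3cccc3)c2)CC1` differs from compound 2 in one place: 1H-pyrrol-1-yl in place of (pyridin-3-yl)methyl on a nitrogen on an aromatic ring. Cut one bond further out, the same difference reads ((pyridin-3-yl)methyl)amino to (1H-pyrrol-1-yl)amino. Going by the values given here, with no measured step to lean on, the expectation rests on compound 2 and its value of 1270 nM, and on the loss of the (pyridin-3-yl)methyl group. A moderate step toward a higher number, beyond the scatter, is expected: a 2.5-fold higher number from compound 2 to compound 3 (0.40 log units; beyond the scatter). Compound 3 is therefore estimated at 3200 nM, with a range from 900 nM to 12000 nM.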

Compound 3, inhibition constant: 481 nM
Compound 3: the middle estimate sits 6.7-fold (0.82 log units) above what was measured, outside the stated range (below it).
By their numbers in this assay, from the lowest: compound 3; then compound 2; then compound 1.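

In this assay, for the compounds shown here, the change from (pyridin-3-yl)methyl to 1H-pyrrol-1-yl on this nitrogen gives a 2.6-fold lower number from compound 2 to compound 3 (0.42 log units; beyond the scatter), the first single-place step that can be read for this series. It shows that the (pyridin-3-yl)methyl group, with its six-membered aromatic ring, is not required for the number seen with compound 2, since a smaller group of 5 heavy atoms with a five-membered aromatic ring gives a lower number in its place. No measurement shown offers an explanation for the step, which therefore stands as an observation only.

This one exchange alters the ring size, the hetero atom's place in the ring and the methyl link to the nitrogen all at once, so the compounds shown leave open which of these changes carries the step. As far as these compounds go, a phenyl group, a benzyl group or an imidazol-1-yl group on the same nitrogen would be needed to separate these changes, and whether a longer chain to the ring would raise or lower the number also remains open.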